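A few compounds are considered here, and "the series" means these few. Any claim that something is new, unique, unknown or untested is made for them only; others in the source may bear on it.

Measured so far:
- compound 1 `CCCC(=O)Nc1cc(Oc2ccc(Nc3nccc4[nH]cc(-c5ccc(F)cc5)c(=O)c34)cc2F)ccn1`: in a functional assay on HT-29 cells (Homo sapiens) for antiproliferative activity, read by MTT assay, with a stated time of 72 h, tested at 10 uM (on this read-out higher numbers stand for more inhibition at the one concentration tested (going by the name of the read-out) and lower numbers for less inhibition), compound 1 gives 23.5%
- compound 2 `CCCCC(=O)Nc1cc(Oc2ccc(Nc3nccc4[nH]cc(-c5ccc(F)cc5)c(=O)c34)cc2F)ccn1`: in this assay compound 2 gives -42.2%

Within the data shown here, compound 2 stands lowest of the two numbers; its nearest neighbour is compound 1, and the one change between them, a number 65.7 percentage points lower from compound 1 to compound 2 (beyond the scatter), was a large move well beyond the scatter, a methyl in place of hydrogen on a saturated chain carbon, three bonds along the chain from a carbonyl carbon.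

Compound 3 `CCC(=O)Nc1cc(Oc2ccc(Nc3nccc4[nH]cc(-c5ccc(F)cc5)c(=O)c34)cc2F)ccn1` is not yet measured in this assay. Relative to compound 2 the change is hydrogen in place of ethyl on a saturated chain carbon, two bonds along the chain from a carbonyl carbon. Read one bond further out, the chain goes from butylcarbonyl to propanoyl, which passes back through the length of compound 1 and continues one carbon shorter.

Among the measured compounds shown here, the only step that bears on this is a number 65.7 percentage points lower from compound 1 to compound 2 (beyond the scatter): lengthening the chain by one carbon cost a great deal of inhibition. Shortening it by two carbons is expected to recover at least that much, so a large rise in this assay is expected, roughly a number 72.2 percentage points higher from compound 2 to compound 3 (beyond the scatter), with wide uncertainty because the shorter chain lies outside the two measured points. For compound 3 the estimate is 30%, between -10% and 65%.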

Compound 3, a percentage reported as inhibition, at one concentration (the size of the read-out at that concentration, not a potency): 68.7%
The estimate for compound 3 lay 38.7 percentage points below the measured number, outside the stated range (above it).
By their numbers in this assay, from the lowest: compound 2; then compound 1; then compound 3.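

In this assay, the chain position now has a third point, and shortening the chain also shifts the number by well beyond the scatter: hydrogen in place of methyl on the saturated chain carbon, two bonds along the chain from the carbonyl carbon, gives a number 45.2 percentage points higher from compound 1 to compound 3 (beyond the scatter), while hydrogen in place of ethyl at that carbon gives a number 110.9 percentage points higher from compound 2 to compound 3 (beyond the scatter). Across these three compounds the inhibition falls with each added carbon, none goes against that order, and the propanoyl compound 3 stands highest, so the earlier single step is now part of a steep trend over a short range of chain lengths rather than an isolated drop from compound 1 to compound 2. Nothing at hand accounts for the steepness of this trend or for the negative number of compound 2.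

Open, on these data alone, is whether the trend continues to the shorter acetyl group or levels off there, and whether a branched chain such as isobutyryl, a cyclopropylcarbonyl group or an amine on the chain would fit it. A reading at one concentration also leaves the potency of compound 3 undefined.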